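The source may report more compounds than this note shows. Statements on the series, on what has been measured and on what is new or still open speak of the compounds shown alone.

Among the compounds with values here, compound 1 `Clc1cccc(Cl)c1Cc1nnc(Nc2ccc(COCc3cccnc3)cc2)o1` is the better tolerated of the two compounds measured so far. In an ADME assay on MT2 cells (Homo sapiens) for cytotoxicity, read by MTT assay (a higher number here means that more compound is tolerated, a lower number that less compound is tolerated), compound 1 gives 81000 nM. The other measured compound, compound 2 `Fc1cccc(F)c1Cc1cnc(Nc2ccc(-c3cccnc3)c(Cl)c2)o1`, differs from compound 1 in several places at once, and in this assay compound 2 gives 8900 nM, a lower number than compound 1.

Compound 3 `Clc1cccc(Cl)c1Cc1nnc(Nc2ccc(COCc3ccncc3)cc2)o1` has not yet been measured. It keeps the same atoms as compound 1, joined differently: pyridin-4-yl in place of pyridin-3-yl on a saturated chain carbon bound to an oxygen on a saturated carbon. Only the point at which the pyridine ring attaches to the chain shifts.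

Within the data shown here, no pair of measured compounds differing in exactly one place is available. There is nothing to calibrate this change against. A shift of one ring nitrogen of this kind is expected to give a step from compound 1 to compound 3 of about a 1.0-fold lower number from compound 1 to compound 3 (0.01 log units; within the scatter), that is, none beyond the usual scatter. Compound 3 is therefore estimated to give 80000 nM in this assay, with a range from 40000 nM to 160000 nM.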

Compound 3, half-maximal cytotoxic concentration: 81000 nM
The estimate for compound 3 lay 1.0-fold (0.01 log units) below the measured number; low and high end bracket the measured number.
By their numbers in this assay, from the lowest: compound 2; then compounds 1 and 3 (each within the scatter of the next).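

In this assay, within the data shown here, the first comparison that differs in one place only shows no change at the digits printed from compound 1 to compound 3 (within the scatter) when pyridin-4-yl takes the place of pyridin-3-yl on a saturated chain carbon bound to an oxygen on a saturated carbon. For this pair, then, moving the point at which the pyridine ring attaches leaves the tolerated concentration unchanged within the usual spread of repeat measurements. Nothing available explains why the two compounds match.

Going by these compounds, what pyridin-2-yl or a plain phenyl ring would give in the same place remains open, so the role of the ring nitrogen itself cannot yet be judged. On these data alone, it is also open whether the same swap would leave the number unchanged on the core of compound 2, where the pyridine ring is carried differently.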